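Triazole-Linked Terpenoid Oximes and Enones: Aryl Swap Expectation

The source may hold more compounds than are shown below. What is called first, only, known or untested is meant among the compounds shown, and "the series" means these compounds.

Compound 1, `COc1cccc(-n2cc(CO/N=C3\CC[C@]4(C)[C@@H](CC/C=C(\C)CC/C=C(\C)CCC=C(C)C)[C@](C)(O)CC[C@H]4C3(C)C)nn2)c1`, gives 21700 nM in a functional assay on A549 cells (Homo sapiens) for cytotoxicity, read by MTT assay, with a stated time of 48 h; a lower number here means a stronger inhibitor, a higher number a weaker inhibitor. Compound 2, `CC(C)=CCC/C(C)=C/CC/C(C)=C/CC[C@@H]1[C@@]2(C)CC/C(=N\OCc3cn(-c4ccc(F)cc4)nn3)C(C)(C)[C@@H]2CC[C@@]1(C)O`, gives 18000 nM in this assay. The change between them, (4-fluorophenyl in place of 3-methoxyphenyl on an aromatic nitrogen), produced a 1.2-fold lower number from compound 1 to compound 2 (0.08 log units; within the scatter).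

Compound 3, `COc1cccc(-n2cc(COc3ccc(/C=C4\C[C@]5(C)[C@@H](CC/C=C(\C)CC/C=C(\C)CCC=C(C)C)[C@](C)(O)CC[C@H]5C(C)(C)C4=O)cc3)nn2)c1`, is built on a different core; how it differs from compound 1 is not broken down here. In this assay compound 3 gives 45700 nM, the highest number of the three compounds.

Compound 4, `CC(C)=CCC/C(C)=C/CC/C(C)=C/CC[C@@H]1[C@@]2(C)C/C(=C\c3ccc(OCc4cn(-c5ccc(F)cc5)nn4)cc3)C(=O)C(C)(C)[C@@H]2CC[C@@]1(C)O`, has not yet been measured. It carries the same change, (4-fluorophenyl in place of 3-methoxyphenyl on an aromatic nitrogen), at the same place. Because a 1.2-fold lower number from compound 1 to compound 2 (0.08 log units; within the scatter) stayed within the scatter, the step from compound 3 to compound 4 is expected to be small as well, about a 1.2-fold lower number from compound 3 to compound 4 (0.08 log units; within the scatter) in this assay. Compound 4 is therefore estimated at 38000 nM, with a likely range from 15000 nM to 95000 nM.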

Compound 4, half-maximal inhibitory concentration: 55200 nM
Estimate against measurement, compound 4: 1.5-fold (0.16 log units) below; measured number inside the range.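

On the second core, the swap of 3-methoxyphenyl for 4-fluorophenyl on the aromatic nitrogen again made little difference in this assay, with a 1.2-fold higher number from compound 3 to compound 4 (0.08 log units; within the scatter). Set beside the earlier step, the change behaved alike on both cores: the same change on two cores in this assay, a 1.2-fold lower number (0.08 log units; within the scatter) from compound 1 to compound 2 and a 1.2-fold higher number (0.08 log units; within the scatter) from compound 3 to compound 4, 1.5-fold (0.16 log units) apart, within the scatter of two such steps. This shows that the swap stayed small on these two cores, but it does not show that it would stay small on a third core, and two pairs cannot establish a general rule for the series.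

The compounds shown leave open what other groups would do at that aromatic nitrogen. A phenyl ring bearing an amine or a carboxylic acid, or an alkyl chain in place of the aryl group, might shift the number further.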